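The source may report more compounds than this note shows. Statements on the series, on what has been measured and on what is new or still open speak of the compounds shown alone.

Working notes on the series.

Within the data shown here, compound 1, `C=C1CCC[C@H]2[C@](C)(CC[C@]3(C)CC[C@H]([C@@H](C)C(=O)O)OO3)[C@@H](C)CC[C@]12C`, is the only member with an actual number in a functional assay on OVCAR-5 cells (Homo sapiens) for inhibition; a lower number here means a stronger inhibitor of growth, a higher number a weaker inhibitor of growth: compound 1 gives 1740 nM. The other two measured compounds sit at limits. For compound 2, `C=C1CCC[C@H]2[C@](C)(CCC(C)=O)[C@@H](C)CC[C@]12C`, the result in this assay is a limit, > 15000 nM, not a number. For compound 3, `C=C1CCCC(C)(C)C1CC[C@]1(C)CC[C@@H]([C@@H](C)C(=O)O)OO1`, the result in this assay is likewise a limit, > 10000 nM. Thus compound 1 stands alone as the measured point of the set, with compound 2 at the limit of > 15000 nM in this assay, at which 1 of the 3 values shown sits, and compound 3 at the limit of > 10000 nM in this assay, at which 1 of the 3 values shown sits; no step between two measured compounds with a single change is available.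

The unmeasured compound 4, `C=C1CCC[C@H]2[C@](C)(CC[C@]3(C)CC[C@@H]([C@@H](C)C(=O)O)OO3)[C@@H](C)CC[C@]12C`, differs from compound 1 as follows: the two compounds have the same atoms and bonds and differ only in configuration as drawn: 1 of 7 stereo elements differ; a stereocentre at a saturated ring carbon is drawn R in compound 1 and S in compound 4. No measured pair shows what a change of configuration alone does here, so the expectation for compound 4 cannot be anchored on a shown step. The working assumption is that the result in this assay moves towards weaker inhibition, with the expected step from compound 1 to compound 4 being a 2.3-fold higher number from compound 1 to compound 4 (0.36 log units; beyond the scatter), though a result within the scatter of compound 1 remains plausible. For compound 4 the estimated value in this assay is 4000 nM, expected to fall between 1200 nM and 15000 nM.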

Compound 4, concentration for 50% growth inhibition: 2720 nM
The estimate for compound 4 lay 1.5-fold (0.17 log units) above the measured number; the measured number falls inside the stated range.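

Among these compounds, the only single-change step in this assay sits at a stereocentre at a saturated ring carbon, and it reads a 1.6-fold higher number from compound 1 to compound 4 (0.19 log units; within the scatter). Among the compounds shown here, neither drawing of this ring carbon, R or S, can be ranked over the other in this read-out, which is something the earlier compounds could not address, as none of them formed a pair with a single change. The comparison isolates configuration at this one centre, with nothing entering or leaving the structure: the fact that compounds 1 and 4 differ only in the configuration as drawn

Going by these compounds, whether a methyl ester or a primary amide could take the place of the carboxylic acid while keeping a measurable number in this assay stays open, as does the effect of inverting any of the other stereo elements. The results for compound 2 and compound 3 are limits rather than numbers, and neither compound is joined to another by a single-change step, leaving the contribution of each part of the core of compound 1 unresolved.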